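The source may hold more compounds than are shown below. What is called first, only, known or untested is meant among the compounds shown, and "the series" means these compounds.

Measured so far:
compound 1 `O=C(Nc1cccc(-n2cc(-c3ccncc3)c(-c3ccc(Cl)c(O)c3)n2)c1)Nc1cccc(C(F)(F)F)c1` — 3180 nM
compound 2 `COc1cc(-c2nn(-c3cccc(NC(=O)Nc4cccc(C(F)(F)F)c4)c3)cc2-c2ccncc2)ccc1Cl` — 1100 nM

In a functional assay on OVCAR-4 cells (Homo sapiens) for inhibition, read by sulforhodamine B assay, with a stated time of 48 h (a lower number here means a stronger inhibitor of growth, a higher number a weaker inhibitor of growth), compound 1 gives the higher of the two numbers; its nearest neighbour is compound 2, reached by a 2.9-fold lower number from compound 1 to compound 2 (0.46 log units; beyond the scatter) through methyl in place of hydrogen on an oxygen on an aromatic ring.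

Compound 3 `O=C(Nc1cccc(-n2cc(-c3ccncc3)c(-c3ccc(Cl)c(O)c3)n2)c1)Nc1ccc(Cl)c(C(F)(F)F)c1` is not yet measured. It differs from compound 1 by chloro in place of hydrogen on an aromatic carbon. For the measured compounds named here, no measured step touches this ring: the only step in hand, from compound 1 to compound 2, sits on the other aryl group and says nothing about adding chloro to the ring carrying the trifluoromethyl group. Without a comparable step, the expectation for compound 3 is that a 1.3-fold lower number from compound 1 to compound 3 (0.10 log units; within the scatter) stays small, likely within the scatter, with no clear direction. Compound 3 is therefore estimated at 2500 nM, with a range from 800 nM to 7000 nM.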

Compound 3, concentration for 50% growth inhibition: 1200 nM
Estimate against measurement, compound 3: 2.1-fold (0.32 log units) above; low and high end bracket the measured number.
By their numbers in this assay, from the lowest: compounds 2 and 3 (each within the scatter of the next); then compound 1.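

In this assay, the ring carrying the trifluoromethyl group responds to a single added atom: chloro in place of hydrogen, ortho to the trifluoromethyl group and para to a large group, gives a 2.7-fold lower number from compound 1 to compound 3 (0.42 log units; beyond the scatter). For the compounds shown here, this is the first reading on that ring, and it shows that the potency of compound 1 can shift through this ring as well as through the other aryl group, by a modest step that lies beyond the scatter. No available measurement bears on the origin of this step.

Going by these compounds, whether the step is specific to chloro remains open, since fluoro, methyl, a nitrile or an amine on the same carbon could give a different result. Also open, on these data alone, is whether chloro at this position and methyl on the oxygen would add up within one compound.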